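Amide to Sulfonyl on the Shared Core

A few compounds are considered here, and "the series" means these few. Any claim that something is new, unique, unknown or untested is made for them only; others in the source may bear on it.

Within the data shown here, compound 1 `CN(C(=O)c1ccc(F)cc1)c1ccc2[nH]c(-c3n[nH]c4ccccc34)cc2n1` is the one compound with a number in a functional assay on SMMC-7721 cells (Homo sapiens) for antiproliferative activity, read by MTT assay, with a stated time of 72 h (on this read-out lower numbers stand for stronger inhibition and higher numbers for weaker inhibition), where compound 1 gives 9150 nM. Compound 2 `CN(C(=O)c1ccccc1)c1ccc2[nH]c(-c3n[nH]c4cc(C#N)ccc34)cc2n1` reaches only a limit of this assay: compound 2 gives > 50000 nM, which is a limit and not a number, as the limit of > 50000 nM in this assay, at which 1 of the 2 values shown sits, records. Compound 3 `CN(c1ccc2[nH]c(-c3n[nH]c4ccccc34)cc2n1)S(=O)(=O)c1ccc(Br)cc1` carries (4-bromophenyl)sulfonyl in place of (4-fluorophenyl)carbonyl on a nitrogen on an aromatic ring. Among the measured compounds shown here, no measured step between compounds stands alongside it, so he expects the change from compound 1 to compound 3 to be a 1.6-fold higher number from compound 1 to compound 3 (0.21 log units; within the scatter), a step not beyond the usual scatter. On that basis compound 3 is estimated at 15000 nM, with a range from 4000 nM to 60000 nM.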

Compound 3, half-maximal inhibitory concentration: 11500 nM
Compound 3: middle estimate off by 1.3-fold (0.12 log units), on the high side; the range from low to high includes it.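

Putting (4-bromophenyl)sulfonyl in place of (4-fluorophenyl)carbonyl on this nitrogen on an aromatic ring gives a 1.3-fold higher number from compound 1 to compound 3 (0.10 log units; within the scatter) in this assay. Among these compounds, this is the first step read at this position, and it shows that the two groups cannot be told apart on this read-out, although the linking group and the halogen both differ. Nothing measured here bears on this result.

The step does not separate the share of the sulfonyl from that of the bromine. From the compounds shown here alone, how an amine or a carboxylic acid would read in this place also stays open.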